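From a Pyrrolidine Amide to a Benzyl Amide

A few compounds are considered here, and "the series" means these few. Any claim that something is new, unique, unknown or untested is made for them only; others in the source may bear on it.

In a functional assay on A549 cells (Homo sapiens) for antiproliferative activity, read by sulforhodamine B assay, with a stated time of 48 h (on this read-out lower numbers stand for stronger inhibition and higher numbers for weaker inhibition), compound 1 (`COc1ccc(C[C@@H](O)/C=C/C=C/C(=O)N2CCN(C)CC2)cc1OC`) gives 22200 nM, compound 2 (`CCN1CCN(C(=O)/C=C/C=C/[C@H](O)Cc2ccc(OC)c(OC)c2)CC1`) gives 15700 nM and compound 3 (`COc1ccc(C[C@@H](O)/C=C/C=C/C(=O)N2CCCC2)cc1OC`) gives 24400 nM. For the measured compounds named here, compound 3 therefore stands level with the other two, and the only remaining step among them, a 1.4-fold lower number from compound 1 to compound 2 (0.15 log units; within the scatter), is also small.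

Compound 4 (`COc1ccc(C[C@@H](O)/C=C/C=C/C(=O)NCc2ccccc2)cc1OC`) keeps the shared core and differs on the carbonyl carbon, with benzylamino in place of pyrrolidin-1-yl on a carbonyl carbon. The most relevant evidence comes from the two measured exchanges at that same place, a 1.1-fold higher number from compound 1 to compound 3 (0.04 log units; within the scatter) and a 1.6-fold higher number from compound 2 to compound 3 (0.19 log units; within the scatter). Going by the values given here, neither step leaves the scatter, but no measured compound carries benzylamino there, so the basis for the expectation is thin. No step beyond the scatter is therefore expected in this assay. The expected change is a 1.2-fold lower number from compound 3 to compound 4 (0.09 log units; within the scatter). Compound 4 is estimated at 20000 nM, with an expected range from 8000 nM to 45000 nM.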

Compound 4, half-maximal inhibitory concentration: 17100 nM
Estimate against measurement, compound 4: 1.2-fold (0.07 log units) above; low and high end bracket the measured number.
By their numbers in this assay, from the lowest: compounds 2, 4, 1 and 3 (each within the scatter of the next).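

In this assay, benzylamino brings to the carbonyl carbon a six-membered aromatic ring of carbon only and an amide hydrogen, neither of which the earlier groups at this place carry, yet the steps stay small: a 1.4-fold lower number from compound 3 to compound 4 (0.15 log units; within the scatter), a 1.1-fold higher number from compound 2 to compound 4 (0.04 log units; within the scatter) and a 1.3-fold lower number from compound 1 to compound 4 (0.11 log units; within the scatter). The range of groups tried on this carbonyl carbon is thus wider than before, now covering a secondary amide as well as tertiary ones, and no exchange among them leaves the scatter. Nothing measured here accounts for this flat response.

Going by these compounds, whether phenethylamino, with its longer chain, or a carboxylic acid in place of the amide would give a step beyond the scatter remains open. N-methylbenzylamino would be needed to separate the amide hydrogen from the aromatic ring, and its effect also remains unknown.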